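A few compounds are considered here, and "the series" means these few. Any claim that something is new, unique, unknown or untested is made for them only; others in the source may bear on it.

Compound 1, `O=C(Nc1ccc(C(=O)N2CCOCC2)cc1)c1cn(Cc2c(F)cccc2F)c2ccc(=O)[nH]c2c1=O`, in an in vitro assay on Sf21 cells for inhibition of high affinity 3',5'-cyclic-AMP phosphodiesterase 7A (Homo sapiens), read by scintillation proximity assay, with a stated time of 30 min (a lower number here means a stronger inhibitor, a higher number a weaker inhibitor), gives 188 nM.
Compound 2, `O=C(Nc1ccc(S(=O)(=O)Nc2nccs2)cc1)c1cn(Cc2c(F)cccc2F)c2ccc(=O)[nH]c2c1=O`, in this assay gives 25 nM.
Compound 3, `CN(C)c1ccc(NC(=O)c2cn(Cc3c(F)cccc3Cl)c3ccc(=O)[nH]c3c2=O)cc1`, in this assay gives 39 nM.

Compound 3 holds the second highest of the three numbers. Its number and that of compound 2 lie within the usual scatter of each other, so nothing separates them. Against compound 1 the gap is beyond the scatter, with compound 1 carrying the higher number, but no single change links these two, so only the two values themselves can be compared.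

Compound 4, `NC(=O)c1ccc(NC(=O)c2cn(Cc3c(F)cccc3Cl)c3ccc(=O)[nH]c3c2=O)cc1`, differs from compound 3 in one place: carbamoyl in place of dimethylamino on an aromatic carbon. Going by the values given here, the only measured step that touches this position is a 7.5-fold lower number from compound 1 to compound 2 (0.88 log units; beyond the scatter), where one group on that same aromatic carbon was replaced by another. That step was modest in size, and neither group involved in it appears in the present change, so it gives no direct guide to dimethylamino or carbamoyl. Among the compounds with values here, with only one relevant step, and that one on different groups, the expectation is a small change at most, if any beyond the scatter: the step from compound 3 to compound 4 in this assay is estimated as a 1.5-fold higher number from compound 3 to compound 4 (0.19 log units; within the scatter). Compound 4 is therefore expected to give about 60 nM in this assay, within a range from 20 nM to 200 nM.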

Compound 4, half-maximal inhibitory concentration: 10 nM
Beside the measured number, compound 4's estimate is 6.0-fold (0.78 log units) above it; measured number below the stated range.
By their numbers in this assay, from the lowest: compound 4; then compounds 2 and 3 (each within the scatter of the next); then compound 1.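

Putting carbamoyl in place of dimethylamino on this aromatic carbon, para to a large group, gives a 3.9-fold lower number from compound 3 to compound 4 (0.59 log units; beyond the scatter), so this position also responds to a change between small groups, which the earlier step between two larger groups could not show. Both groups have the same count of heavy atoms, so heavy-atom count alone does not set the number here; what differs is that carbamoyl brings a carbonyl oxygen, a double bond outside the aromatic rings and a hydrogen-bond donor, while dimethylamino brings none of these. Nothing measured here gives a reason for this drop in the number, and the step by itself records only its size.

As far as these compounds go, it remains open which feature of carbamoyl goes with the lower number: a dimethylcarbamoyl group would keep the carbonyl without the amide hydrogens, while a carboxylic acid or a plain amine would alter the group in other ways. From the compounds shown here alone, it is also open whether the same swap would give a step of similar size on the core of compound 1, with its different halogen pattern on the benzyl group.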